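Fluoro to Nitro on the Phenyl Ring: Cytotoxicity Outlook

The source may report more compounds than this note shows. Statements on the series, on what has been measured and on what is new or still open speak of the compounds shown alone.

Measured so far:
compound 1, `Cc1cc(-c2ccccc2)c2ncc(CSCCc3ccccc3)n2c1`: 20 ug/mL
compound 2, `Cc1cc(-c2cccc(F)c2)c2ncc(CSCCc3ccccc3)n2c1`: 20 ug/mL

Compound 1 and compound 2 share one core and differ only on the phenyl ring attached to it. In an ADME assay on HEL cells (Homo sapiens) for cytotoxicity, with a stated time of 3 days (on this read-out lower numbers stand for higher toxicity in this test and higher numbers for lower toxicity in this test), compound 1 gives 20 ug/mL and compound 2 gives 20 ug/mL. Within the data shown here, the single measured step, no change at the digits printed from compound 1 to compound 2 (within the scatter), shows that a fluoro in place of hydrogen on that ring left the read-out where it was, within the scatter. On the numbers known, compound 2 stands level with compound 1.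

Compound 3 `Cc1cc(-c2cccc([N+](=O)[O-])c2)c2ncc(CSCCc3ccccc3)n2c1` has not yet been measured. It differs from compound 2 as follows: nitro in place of fluoro on an aromatic carbon. Among the measured compounds shown here, the only step that bears on this change is no change at the digits printed from compound 1 to compound 2 (within the scatter), which altered the same phenyl ring and stayed within the scatter. Nothing in the data points to a shift, so no step beyond the scatter is expected in this assay. The expected step for compound 3 is no change at the digits printed from compound 2 to compound 3 (within the scatter). Compound 3 is estimated at 20 ug/mL, with a range from 10 ug/mL to 40 ug/mL.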

Compound 3, minimum cytotoxic concentration: 100 ug/mL
For compound 3 the middle estimate is 5.0-fold (0.70 log units) below the measured one, outside the stated range (above it).
By their numbers in this assay, from the lowest: compounds 1 and 2 (each within the scatter of the next); then compound 3.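

Swapping one group at this position on the phenyl ring can move the read-out, something compounds 1 and 2 alone could not show, as they sat level with each other. In this assay, placing nitro where fluoro stood gives a 5.0-fold higher number from compound 2 to compound 3 (0.70 log units; beyond the scatter), and placing nitro where hydrogen stood gives a 5.0-fold higher number from compound 1 to compound 3 (0.70 log units; beyond the scatter), so nitro separates itself from both fluoro and hydrogen, and the higher number means lower toxicity in this test. No measurement here accounts for why nitro behaves differently from the other two groups.

The compounds shown leave open whether the higher number belongs to nitro alone or would also appear with other groups on this aromatic carbon, such as an amine, a carboxylic acid or a nitrile. They also leave open whether nitro would give a step of the same size elsewhere on the phenyl ring, or in a compound with a longer or shorter chain in place of the one shared by all three.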